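Hydroxy to Chloro: An Expected Loss of Potency

This account rests on a few compounds, and the source may have more. Where it says the series, first, only, none or still open, it means among the compounds named here.

Compound 1 `Cc1ccc(C(=O)N/N=C/c2ccccc2O)c(O)c1` gives 1020 nM in a functional assay (Mus musculus, strain BALB/C) for inhibition, read by MTT assay, with stated times of 24 h and 72 h (a lower number here means a stronger inhibitor, a higher number a weaker inhibitor), the lowest of the three numbers measured. Compound 2 `Cc1ccc(C(=O)N/N=C/c2ccc(Cl)cc2)c(O)c1` gives 12300 nM and compound 3 `Cc1ccc(C(=O)N/N=C/c2ccc(F)cc2)c(O)c1` gives 26700 nM; both carry a halogen instead of a hydroxy and both sit far above compound 1. Within the data shown here, the only single-point step measured, a 2.2-fold higher number from compound 2 to compound 3 (0.34 log units; beyond the scatter), concerns one halogen replacing another and does not directly test the change at hand. Compound 4 `Cc1ccc(C(=O)N/N=C/c2ccccc2Cl)c(O)c1` differs from compound 1 by chloro in place of hydroxy on an aromatic carbon. Compound 2, which also lacks the hydroxy, gives 12300 nM and is the nearest guide. Compound 4 is therefore expected to lose potency, a 5.9-fold higher number from compound 1 to compound 4 (0.77 log units; beyond the scatter). Compound 4 is estimated at 6000 nM, within 1500 nM to 25000 nM.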

Compound 4, half-maximal inhibitory concentration: 19200 nM
Compound 4: the middle estimate sits 3.2-fold (0.51 log units) below what was measured; the range from low to high includes it.
By their numbers in this assay, from the lowest: compound 1; then compounds 2, 4 and 3 (each within the scatter of the next, the first and the last beyond it).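

In this assay, among these compounds, chloro in place of hydroxy on this aromatic carbon gives a 19-fold higher number from compound 1 to compound 4 (1.27 log units; beyond the scatter) and this is the first change at this position made on its own. Among the compounds shown here, compound 2 and compound 3 each differ from compound 1 in more than one place, so only this pair ties the loss to this single swap. No measurement available explains the loss. Still open, on these data alone, is whether another group on this carbon, such as methoxy or an amine, or plain hydrogen, would keep the potency of compound 1.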